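Trifluoromethyl in Place of Hydrogen on Compound 2

The source may report more compounds than this note shows. Statements on the series, on what has been measured and on what is new or still open speak of the compounds shown alone.

Compound 2 `O=c1c(-c2nn[nH]n2)c[nH]c2ccccc12` gives 1.25 mg/kg in a functional assay on the whole organism (strain Sprague-Dawley) for inhibition, with Rattus norvegicus as the target (a higher number here means that more compound is needed for the effect, a lower number that less compound is needed), and stands level with compound 3 `Cc1ccc2[nH]cc(-c3nn[nH]n3)c(=O)c2c1`, which gives 1.25 mg/kg; the step of no change at the digits printed from compound 2 to compound 3 (within the scatter) stays within the scatter. Compound 1 `O=c1c(-c2nn[nH]n2)c[nH]c2c(Br)cccc12` reaches only a limit of this assay, namely (the limit of > 5 mg/kg in this assay, at which 1 of the 3 values shown sits), so its value > 5 mg/kg is a limit and not a number. The change to compound 4 `O=c1c(-c2nn[nH]n2)c[nH]c2c(C(F)(F)F)cccc12` is trifluoromethyl in place of hydrogen on an aromatic carbon. The measured step that bears on it is an at least 4.0-fold lower number from compound 1 to compound 2 (0.60 log units; beyond the scatter), where removing a substituent from an aromatic carbon of the core gained potency. A loss beyond the scatter is therefore expected, and the expected step is a 4.0-fold higher number from compound 2 to compound 4 (0.60 log units; beyond the scatter). Compound 4 is expected to give 5 mg/kg, with a range of 1.5 mg/kg to 15 mg/kg, and may well be reported only as a limit.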

Compound 4, minimum effective dose: 0.156 mg/kg
Compound 4: the middle estimate sits 32-fold (1.51 log units) above what was measured, outside the stated range (below it).
By their numbers in this assay, from the lowest: compound 4; then compounds 2 and 3 (each within the scatter of the next). At a limit, above all of these: compound 1.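

In this assay, trifluoromethyl on the aromatic carbon that carries bromo in compound 1 gives an 8.0-fold lower number from compound 2 to compound 4 (0.90 log units; beyond the scatter), so a substituent at this carbon does not in itself cost potency. Trifluoromethyl in place of bromo gives an at least 32-fold lower number from compound 1 to compound 4 (1.50 log units; beyond the scatter), so the outcome at this carbon depends on the group and not on substitution alone. The figure for compound 1 is a limit and not a number: the limit of > 5 mg/kg in this assay, at which 1 of the 4 values shown sits.

Going by these compounds, it remains open how a methoxy group, a chloro group or a nitrile would behave at this carbon. Also open, on these data alone, is whether trifluoromethyl on another aromatic carbon of the shared core would give a similar result.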